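Hydroxymethyl in place of methoxycarbonyl: working notes

The compounds below may be only part of what the source reports. "The series", "measured", "known", "first", "only" and "open" are said of these compounds alone.

Going by the values given here, in a functional assay on KBVIN cells (Homo sapiens) for cytotoxicity, read by sulforhodamine B assay, with a stated time of 3 days (a lower number here means that less compound is needed, a higher number that more compound is needed for the effect), compound 1 (`COC(=O)c1c(C)coc1-c1ccc2c(c1OC)CCCC2(C)C`) gives 52.1 uM, the higher of the two numbers available so far. Compound 2 (`CCc1cccc2c(O)c(-c3occ(C)c3C(=O)O)ccc12`) gives 23.6 uM, a lower number, and the gap between the two lies beyond the usual scatter. These two compounds differ in more than one place, so their values do not isolate any single structural change.

Compound 3 (`COc1c(-c2occ(C)c2CO)ccc2c1CCCC2(C)C`), still to be measured, keeps the core of compound 1 and carries hydroxymethyl in place of methoxycarbonyl on an aromatic carbon. Among the compounds with values here, no measured pair isolates this exchange, which leaves the expectation weakly founded. The only guide is compound 2, whose 23.6 uM shows that a lower number occurs among these compounds. A small move toward a lower number in this assay is therefore expected, and it may stay within the scatter. The estimated step of a 1.6-fold lower number from compound 1 to compound 3 (0.20 log units; within the scatter) is modest. Compound 3 is estimated at 33 uM, with an expected range from 13 uM to 75 uM.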

Compound 3, concentration for half-maximal effect: 21.7 uM
The estimate for compound 3 lay 1.5-fold (0.18 log units) above the measured number; the range from low to high includes it.
By their numbers in this assay, from the lowest: compounds 3 and 2 (each within the scatter of the next); then compound 1.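

In this assay, going by these compounds alone, placing hydroxymethyl in place of methoxycarbonyl on an aromatic carbon of the five-membered aromatic ring with 1 oxygen gives a 2.4-fold lower number from compound 1 to compound 3 (0.38 log units; beyond the scatter) and provides the first single-place comparison, with a step beyond the scatter. This shows that the number responds to the group at this position, two ring bonds from the ring oxygen, and that methoxycarbonyl is not required there for activity at this level on the core of compound 1. The entering group has fewer heavy atoms and carries a hydrogen-bond donor that methoxycarbonyl lacks, but no measurement bears on why the number changes.

Within the data shown here, the single pair cannot separate the contribution of the hydrogen-bond donor from that of the smaller group, and methoxymethyl or aminomethyl at the same position on the core of compound 1 would help to tell these readings apart. Among these compounds, it also remains open whether this exchange gives a step of similar size on another core, since compound 1 and compound 3 are the only pair that isolates it.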